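From benzyl to (3,4-dichlorophenyl)carbonyl

The source may report more compounds than this note shows. Statements on the series, on what has been measured and on what is new or still open speak of the compounds shown alone.

Measured in a functional assay on MCF7 cells (Homo sapiens) for antiproliferative activity, read by MTT assay, with a stated time of 72 h; on this read-out lower numbers stand for stronger inhibition and higher numbers for weaker inhibition:
Compound 1 `CC1=CC[C@H]2[C@@H]1CC=C(C)[C@@H](CC[C@H]1[C@]3(C)CC[C@H](O)C(C)(C)O[C@H]3CC[C@@]1(C)O)C2(C)C`: > 50000 nM
Compound 2 `CC1=CC[C@H]2[C@@H]1CC=C(C)[C@@H](CC[C@H]1[C@]3(C)CC[C@H](OC(=O)c4ccncc4)C(C)(C)O[C@H]3CC[C@@]1(C)O)C2(C)C`: > 50000 nM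
Compound 3 `CC1=CC[C@H]2[C@H](CC[C@]2(C)O)C(C)(C)[C@@H]1CC[C@H]1[C@]2(C)CC[C@H](OCc3ccccc3)C(C)(C)O[C@H]2CC[C@@]1(C)O`: > 50000 nM

Each of these values is a limit of the assay and not a number, as the limit of > 50000 nM in this assay, at which 3 of the 3 values shown sit, shows. Compound 3 therefore stands only at the limit of > 50000 nM. Compound 4 `CC1=CC[C@H]2[C@H](CC[C@]2(C)O)C(C)(C)[C@@H]1CC[C@H]1[C@]2(C)CC[C@H](OC(=O)c3ccc(Cl)c(Cl)c3)C(C)(C)O[C@H]2CC[C@@]1(C)O` carries (3,4-dichlorophenyl)carbonyl in place of benzyl on an oxygen on a saturated carbon. The nearest measured change, a step that the two limits leave unreadable from compound 1 to compound 2, also places a carbonyl-bearing group on such an oxygen, but it has no readable size. Compound 2 offers only the limit of > 50000 nM. Among the measured compounds shown here, no step of definite size or direction is therefore expected in this assay. The expected step is a number no higher from compound 3 to compound 4 (the limit leaves the size open). For compound 4 the estimated value is 50000 nM, with an expected range of 20000 nM to 100000 nM.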

Compound 4, half-maximal inhibitory concentration: 11900 nM
Compound 4: middle estimate off by 4.2-fold (0.62 log units), on the high side; measured number below the stated range.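

In this assay, this oxygen on a saturated carbon proves responsive to the group it carries: (3,4-dichlorophenyl)carbonyl in place of benzyl gives an at least 4.2-fold lower number from compound 3 to compound 4 (0.62 log units; beyond the scatter). Among the compounds shown here, the earlier step between compound 1 and compound 2 could not be read, so this is the only readable change at this position. Compound 4 alone gives a number rather than a limit: the limit of > 50000 nM in this assay, at which 3 of the 4 values shown sit.

As far as these compounds go, the full size of the step stays open, with compound 3 held at a limit. Also open, from the compounds shown here alone, is whether the carbonyl or the two chlorines carry the change, and whether an amine or a longer chain on this oxygen would do the same.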